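Changing the Sulfonyl Aryl Group on Two Benzoxazole Cores

The source may report more compounds than this note shows. Statements on the series, on what has been measured and on what is new or still open speak of the compounds shown alone.

This set contains two pairs of sulfonamides built on two different cores. The cores of compound 1 `Cc1ccccc1S(=O)(=O)Nc1ccc2oc(-c3ccccc3)nc2c1` and compound 3 `Cc1ccccc1S(=O)(=O)Nc1ccc(-c2nc3ccccc3o2)cc1` are made of the same atoms joined differently; the difference between the two cores is not broken down here. Within each pair the group on the sulfonyl sulfur is exchanged.

In an ADME assay on HEK293 cells (Homo sapiens) for cytotoxicity, read by resazurin assay, with a stated time of 48 h (a higher number here means that more compound is tolerated, a lower number that less compound is tolerated), compound 1 gives 57000 nM. Compound 2 `COc1ccc(Cl)cc1S(=O)(=O)Nc1ccc2oc(-c3ccccc3)nc2c1` carries the change 5-chloro-2-methoxyphenyl in place of 2-methylphenyl on a sulfonyl sulfur and gives 74000 nM in this assay. The resulting step, a 1.3-fold higher number from compound 1 to compound 2 (0.11 log units; within the scatter), is small. For compound 3 the assay reports only a limit, > 100000 nM, in this assay; this is a limit of the measurement and not a number, as noted in the limit of > 100000 nM in this assay, at which 1 of the 3 values shown sits.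

Compound 4 `COc1ccc(Cl)cc1S(=O)(=O)Nc1ccc(-c2nc3ccccc3o2)cc1` has not yet been measured. Among the compounds with values here, it differs from compound 3 by 5-chloro-2-methoxyphenyl in place of 2-methylphenyl on a sulfonyl sulfur, which is the same change as the one from compound 1 to compound 2, made at the same place. Because compound 1 to compound 2 gave a 1.3-fold higher number from compound 1 to compound 2 (0.11 log units; within the scatter), the same change on the core of compound 3 is expected to produce a step that the limit leaves unreadable from compound 3 to compound 4 in this assay. Since compound 3 already sits at the limit, compound 4 is estimated at roughly 130000 nM, with a likely range from 70000 nM to 300000 nM, and a good chance that the assay again reports only a limit.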

Compound 4, half-maximal cytotoxic concentration: 75000 nM
Compound 4: the middle estimate sits 1.7-fold (0.24 log units) above what was measured; measured number inside the range.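

On the core of compound 3, putting 5-chloro-2-methoxyphenyl in place of 2-methylphenyl on the sulfonyl sulfur gives an at least 1.3-fold lower number from compound 3 to compound 4 (0.12 log units; that floor lies within the scatter) in this assay. Within the data shown here, only one end of this step is a number, since the value for compound 3 is a limit of the assay: the limit of > 100000 nM in this assay, at which 1 of the 4 values shown sits. The comparison therefore does not show that the change carries over unaltered from one core to the other, and it does not show that the two cores respond differently either: the same change on two cores in this assay, a 1.3-fold higher number (0.11 log units; within the scatter) from compound 1 to compound 2 and an at least 1.3-fold lower number (0.12 log units; that floor lies within the scatter) from compound 3 to compound 4; the limit leaves it open whether they differ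

The compounds shown place only these two aryl groups on the sulfonyl sulfur, which leaves open how an amine, a carboxylic acid or a longer chain in that place would read in this assay. Also open, as far as these compounds go, is whether the same change would give matching steps on the two cores if both ends of each step were numbers, and a further pair on the core of compound 3 with two numbers would be needed to settle that.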